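Swapping 1-carboxyethyl for 1-carboxy-1-methylethyl on compound 3

The source may hold more compounds than are shown below. What is called first, only, known or untested is meant among the compounds shown, and "the series" means these compounds.

Compound 1 `O=C(O)Cn1nc(Cc2nc3cc(Cl)c(OCC(F)F)cc3[nH]2)c2ccccc2c1=O`: < 56.7 mL/min/kg
Compound 2 `O=C(O)Cn1nc(Cc2nc3cc(F)c(OCC4CC4)cc3[nH]2)c2ccccc2c1=O`: < 53.4 mL/min/kg
Compound 3 `C[C@@H](C(=O)O)c1nn(Cc2cn3cc(OCC4CC4)c(Cl)cc3n2)c2ccccc2c1=O`: < 55 mL/min/kg

All three results come from an ADME assay on microsomes from liver (Mus musculus) for metabolic stability; a higher number here means faster removal of the compound, a lower number slower removal. Compound 3 stands at < 55 mL/min/kg, which is a limit and not a number. The results for compound 1 and compound 2 are limits too, so no exact clearance is known for any of the three.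

Compound 4 `CC(C)(C(=O)O)c1nn(Cc2cn3cc(OCC4CC4)c(Cl)cc3n2)c2ccccc2c1=O` carries 1-carboxy-1-methylethyl in place of 1-carboxyethyl on an aromatic carbon. Going by the values given here, no measured pair shows what this change does. With only the limit of < 55 mL/min/kg for compound 3 as a guide, no step beyond the usual scatter is expected in this assay. The expected change is a step that the limit leaves unreadable from compound 3 to compound 4. The estimate for compound 4 is 48 mL/min/kg, with an expected range of 28 mL/min/kg to 60 mL/min/kg.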

Compound 4, clearance: < 63.4 mL/min/kg
Compound 4 was reported as a limit (the forecaster's own chance of this, stated with the estimate: 75%); the middle value does not contradict the limit.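

No step can be read between compound 3 and compound 4, since in this assay each is reported only as a limit. Whether 1-carboxy-1-methylethyl in place of 1-carboxyethyl alters clearance at all remains open, as does the exact clearance of every compound shown.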